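Phenyl substituent series: trifluoromethoxy replaced by hydroxy

The source may hold more compounds than are shown below. What is called first, only, known or untested is meant among the compounds shown, and "the series" means these compounds.

Compound 3 `COC(=O)C1=C(C)N=C(C)/C(=C(/O)OC)C1c1cccc(N/C(=N/CCNC2CCN(c3ccccc3OC(F)(F)F)CC2)NC#N)c1` gives 28 nM in an assay on SK-N-MC cells for inhibition of Neuropeptide Y receptor type 1 (Homo sapiens) (a lower number here means a stronger inhibitor, a higher number a weaker inhibitor), the highest number among the three measured compounds. Compound 1 `COC(=O)C1=C(C)N=C(C)/C(=C(/O)OC)C1c1cccc(N/C(=N/CCNC2CCN(c3ccccc3)CC2)NC#N)c1` gives 10 nM, and compound 2 `COC(=O)C1=C(C)N=C(C)/C(=C(/O)OC)C1c1cccc(N/C(=N/CCNC2CCN(c3ccccc3C#N)CC2)NC#N)c1` gives 3 nM. The measured steps are a 3.3-fold lower number from compound 1 to compound 2 (0.52 log units; beyond the scatter), a 2.8-fold higher number from compound 1 to compound 3 (0.45 log units; beyond the scatter) and a 9.3-fold higher number from compound 2 to compound 3 (0.97 log units; beyond the scatter). Compound 4 `COC(=O)C1=C(C)N=C(C)/C(=C(/O)OC)C1c1cccc(N/C(=N/CCNC2CCN(c3ccccc3O)CC2)NC#N)c1` differs from compound 3 by hydrogen in place of trifluoromethyl on an oxygen on an aromatic ring. For the measured compounds named here, no measured step introduces a hydroxy group, so the only step that bears on this change is a 2.8-fold higher number from compound 1 to compound 3 (0.45 log units; beyond the scatter), which shows what the trifluoromethoxy group itself contributed when compared with hydrogen. Reading that step in reverse, compound 4 is expected to show a modest lower number in this assay, close to compound 1, that is a 2.3-fold lower number from compound 3 to compound 4 (0.37 log units; beyond the scatter). The estimate for compound 4 is 12 nM, with a range from 4 nM to 40 nM.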

Compound 4, half-maximal inhibitory concentration: 5 nM
For compound 4 the middle estimate is 2.4-fold (0.38 log units) above the measured one, within the range that was stated.
By their numbers in this assay, from the lowest: compounds 2, 4 and 1 (each within the scatter of the next, the first and the last beyond it); then compound 3.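

In this assay, hydrogen on the oxygen in place of trifluoromethyl gives a 5.6-fold lower number from compound 3 to compound 4 (0.75 log units; beyond the scatter), so an oxygen on this aromatic carbon does not by itself carry the higher number of compound 3. Hydroxy cannot be told apart from hydrogen, with a 2.0-fold lower number from compound 1 to compound 4 (0.30 log units; within the scatter), or from cyano, with a 1.7-fold higher number from compound 2 to compound 4 (0.22 log units; within the scatter), although compound 1 and compound 2 differ from each other beyond the scatter. No measurement shown accounts for these differences. Open, as far as these compounds go, is how a methoxy group or an amine at this place would read.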